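Nitro to Ethyl on a Shared Core: What to Expect

The source may report more compounds than this note shows. Statements on the series, on what has been measured and on what is new or still open speak of the compounds shown alone.

Compound 1 `CN1CCN(c2nc3cc([N+](=O)[O-])ccc3o2)CC1` and compound 2 `Cc1cc(Cl)c2oc(N3CCN(C)CC3)nc2c1` share a core and differ in the groups attached to its aromatic carbons. In a functional assay on ileum (strain Hartley) for agonist activity at 5-hydroxytryptamine receptor 3A (Cavia porcellus) (a lower number here means a less potent compound, a higher number a more potent compound, by a factor of ten per unit of this negative logarithm), compound 1 gives 6.1 and compound 2 gives 6.22; these two values lie within the usual scatter of each other. Compound 3 `CCc1ccc2oc(N3CCN(C)CC3)nc2c1` has not been measured; it arises from compound 1 by ethyl in place of nitro on an aromatic carbon. Within the data shown here, no measured pair shows this change, so the expected step of a number 0.20 log units higher from compound 1 to compound 3 (within the scatter) is a guess, small and possibly none beyond the scatter. Compound 3 is therefore expected to give about 6.3 in this assay, within a range from 5.6 to 7.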

Compound 3, negative logarithm of the half-maximal effective concentration: < 4
Compound 3: a limit, no number; the forecaster's own chance of this, stated with the estimate: 5%; middle value at least 2.30 log units from the limit.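

In this assay compound 3 gives < 4, a limit of the assay and not a number. Ethyl in place of nitro on this aromatic carbon brings a number at least 2.10 log units lower from compound 1 to compound 3 (beyond the scatter), so the group here can matter greatly, which compound 1 and compound 2, differing in more than one place, could not show. The full size of this step stays unknown: the limit of < 4 in this assay, at which 1 of the 3 values shown sits.

The compounds shown cannot tell whether the loss comes from removing nitro or from adding ethyl. As far as these compounds go, how an amine or a carboxylic acid on this carbon would read also stays open.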